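Adding a Methoxy Group to Compound 2

The compounds below may be only part of what the source reports. "The series", "measured", "known", "first", "only" and "open" are said of these compounds alone.

Compound 1 `COc1ccc(-c2csc(NC(=O)COc3ccc(C(=O)c4ccccc4)cc3C)n2)cc1` gives 27100 nM in a functional assay on Ehrlich cells (Mus musculus) for cytotoxicity, read by trypan blue exclusion, with a stated time of 48 h; a higher number here means a weaker inhibitor, a lower number a stronger inhibitor.
Compound 2 `Cc1cc(C(=O)c2ccccc2)cc(C)c1OCC(=O)Nc1nc(-c2ccccc2)cs1` gives 22100 nM in this assay.

Going by the values given here, of the two numbers so far, compound 2 has the lower one, but its gap to compound 1 lies within the usual scatter, so the two cannot be told apart. Compound 3 `COc1ccc(-c2csc(NC(=O)COc3c(C)cc(C(=O)c4ccccc4)cc3C)n2)cc1` is built from compound 2 by one change: methoxy in place of hydrogen on an aromatic carbon. Among the compounds with values here, no measured pair shows this change on its own; compound 1 carries the methoxy group too, yet it also differs from compound 2 in another place, so its value cannot be read as the effect of the methoxy group alone. With nothing to point either way, the step of a 1.0-fold lower number from compound 2 to compound 3 (0.00 log units; within the scatter) is expected to stay within the scatter, in no particular direction. Compound 3 is therefore estimated at 22000 nM in this assay, with a range from 10000 nM to 50000 nM.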

Compound 3, half-maximal inhibitory concentration: 40600 nM
Beside the measured number, compound 3's estimate is 1.8-fold (0.27 log units) below it; the range from low to high includes it.
By their numbers in this assay, from the lowest: compounds 2, 1 and 3 (each within the scatter of the next).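

Going by these compounds alone, on the phenyl ring of compound 2, going to 4-methoxyphenyl gives a 1.8-fold higher number from compound 2 to compound 3 (0.26 log units; within the scatter) in this assay and so provides the first direct reading of this change: at this position, the methoxy group leaves the number within the scatter. The methyl change elsewhere on the molecule gives a 1.5-fold higher number from compound 1 to compound 3 (0.18 log units; within the scatter) and also stays within the scatter, so neither single change separates its pair of compounds. The numbers alone offer no explanation for these small steps, and no supporting measurement bears on them.

At this position, the compounds shown cover only hydrogen and methoxy, so the outcome with an amine, a carboxylic acid or a longer chain such as ethoxy remains open. Also open, as far as these compounds go, is whether any single change to this series can move the number beyond the scatter.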